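This account rests on a few compounds, and the source may have more. Where it says the series, first, only, none or still open, it means among the compounds named here.

Three compounds sharing one core were measured in an ADME assay on the whole organism for inhibition, with Echinochloa crus-galli var. formosensis as the target, with a stated time of 4 days; a lower number here means a stronger inhibitor, a higher number a weaker inhibitor. Compound 1 `CCN(c1nc(Cl)nc(N[C@H](C)c2ccccc2)n1)C(C)C` gives 52500 nM. Within the data shown here, compound 3 `CC[C@@H](C)Nc1nc(Cl)nc(N[C@H](C)c2ccccc2)n1` gives 4570 nM, and the single change between them, (sec-butyl)amino in place of ethyl(isopropyl)amino on an aromatic carbon, brings an 11-fold lower number from compound 1 to compound 3 (1.06 log units; beyond the scatter). Compound 2 `CCCN(CC)c1nc(Cl)nc(N[C@@H](C)c2ccccc2)n1` gives 282 nM, the lowest of the three numbers; the values of compound 3 and of compound 1 both stand above it by amounts beyond the scatter, so compound 2 is the strongest inhibitor of the three.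

Compound 4 `CCCN(C)c1nc(Cl)nc(N[C@@H](C)c2ccccc2)n1` differs from compound 2 in one place: hydrogen in place of methyl on a saturated chain carbon bound to a nitrogen on an aromatic ring. Read one bond further out, ethyl(propyl)amino becomes methyl(propyl)amino. Among the measured compounds shown here, no measured pair shows this particular change. For the measured compounds named here, the only measured step, an 11-fold lower number from compound 1 to compound 3 (1.06 log units; beyond the scatter), shows that reshaping the amino group on the core can move this assay a long way, but it is a different reshaping and points in no direction for the present one. A modest rise in the number, meaning somewhat weaker inhibition, is expected for compound 4, estimated at 600 nM with a range from 150 nM to 2500 nM. The expected step is a 2.1-fold higher number from compound 2 to compound 4 (0.33 log units; beyond the scatter), though a step within the scatter would not surprise.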

Compound 4, half-maximal inhibitory concentration: 380 nM
The estimate for compound 4 lay 1.6-fold (0.20 log units) above the measured number; the range from low to high includes it.
By their numbers in this assay, from the lowest: compounds 2 and 4 (each within the scatter of the next); then compound 3; then compound 1.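

In this assay, replacing ethyl(propyl)amino with methyl(propyl)amino gives a 1.3-fold higher number from compound 2 to compound 4 (0.13 log units; within the scatter), so removing this one carbon makes no difference that can be told apart from the ordinary spread of repeat measurements. Among these compounds, the earlier compounds showed only that a change to the amino group can have a large effect, as in an 11-fold lower number from compound 1 to compound 3 (1.06 log units; beyond the scatter); this pair adds that at least one change to that group, ethyl to methyl, leaves the number essentially where it was, and compound 2 and compound 4 cannot be ranked against each other. Nothing available here explains why this particular change has so little effect.

From the compounds shown here alone, what remains open is how far this insensitivity extends, since only ethyl and methyl have been compared at this place while the propyl chain stayed fixed. A longer chain such as butyl, a ring such as cyclopropyl, or a hydroxyethyl chain in place of the ethyl could show whether the number stays this low or starts to move.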